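Amino to methoxy: working notes on compound 4

The source may report more compounds than this note shows. Statements on the series, on what has been measured and on what is new or still open speak of the compounds shown alone.

Measured in a functional assay (aorta) with Oryctolagus cuniculus as the target; a lower number here means tighter binding, a higher number weaker binding:
- compound 1 `COC(=O)c1ccc(OCCCN2CCC(C(c3ccc(F)cc3)c3ccc(F)cc3)CC2)c(OC)c1`: 1.26 nM
- compound 2 `CC(=O)c1ccc(OCCCN2CCC(C(c3ccc(F)cc3)c3ccc(F)cc3)CC2)cc1`: 2.51 nM
- compound 3 `Nc1ccc(OCCCN2CCC(C(c3ccc(F)cc3)c3ccc(F)cc3)CC2)cc1`: 31.6 nM

Of the three, compound 3 has the highest number, 31.6 nM. The next structure, compound 4 `COc1ccc(OCCCN2CCC(C(c3ccc(F)cc3)c3ccc(F)cc3)CC2)cc1`, has methoxy in place of amino on an aromatic carbon, para to a large group: methoxy in place of amino on an aromatic carbon. Among the measured compounds shown here, two measured steps bear on this change: a 13-fold higher number from compound 2 to compound 3 (1.10 log units; beyond the scatter) and a 25-fold higher number from compound 1 to compound 3 (1.40 log units; beyond the scatter). Both end at the amino compound, and both are large. For the measured compounds named here, no measured compound has the 4-methoxyphenyl group, so only part of that gap is expected to close in this assay. The expected step is a 4.0-fold lower number from compound 3 to compound 4 (0.60 log units; beyond the scatter), towards a lower number. For compound 4 the estimated value is 8 nM, with an expected range of 2.5 nM to 25 nM.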

Compound 4, dissociation constant: 2.51 nM
Estimate against measurement, compound 4: 3.2-fold (0.50 log units) above; measured number inside the range.
By their numbers in this assay, from the lowest: compounds 1, 2 and 4 (each within the scatter of the next); then compound 3.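

In this assay the change from amino to methoxy gives a 13-fold lower number from compound 3 to compound 4 (1.10 log units; beyond the scatter) and so ties the high number of compound 3 to the amino group, not to the shared core. Methoxy in place of acetyl gives no change at the digits printed from compound 2 to compound 4 (within the scatter) and the 4-methoxyphenyl group in place of 2-methoxy-4-(methoxycarbonyl)phenyl gives a 2.0-fold higher number from compound 1 to compound 4 (0.30 log units; within the scatter) so among the groups shown, amino alone stands apart at this position. Nothing at hand gives a reason for this.
Open, from the compounds shown here alone, is whether a hydroxyl or a dimethylamino group here would side with amino or with methoxy. Going by these compounds, a carboxylic acid at this position is equally open.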